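The source may hold more compounds than are shown below. What is called first, only, known or untested is meant among the compounds shown, and "the series" means these compounds.

Measured in a functional assay on the whole organism (strain Wistar) for inhibition, with Rattus norvegicus as the target, with a stated time of 4 h; a lower number here means that less compound is needed, a higher number that more compound is needed for the effect:
compound 1 `Cc1c(C)c2ccc(OCC(=O)NN)cc2oc1=O`: 9.14 nM
compound 2 `Cc1cc(=O)oc2cc(OCc3nnc(S)o3)ccc12`: 7.85 nM
compound 3 `Cc1cc(=O)oc2cc(OCc3nnc(S)s3)ccc12`: 7.95 nM

Compound 3, at 7.95 nM, does not stand apart from the other two. Its gaps to compound 2 and to compound 1 both lie within the usual scatter of repeated measurements, so these numbers give no ranking.

The next compound, compound 4 `Cc1c(C)c2ccc(OCc3nnc(S)s3)cc2oc1=O`, keeps the side chain of compound 3 and alters the core: methyl in place of hydrogen on an aromatic carbon. In short, this is methyl in place of hydrogen on an aromatic carbon.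

Only one measured step exists among these compounds, a 1.0-fold higher number from compound 2 to compound 3 (0.01 log units; within the scatter). For the measured compounds named here, it changes the side chain and lies within the scatter, so no measured step tests the new methyl directly. The nearest hint is compound 1, which shares the core of compound 4 but has a different side chain. Compound 1 gives 9.14 nM, a value within the scatter of compound 3. On that basis, no change beyond the scatter is expected, and the estimated step is a 1.1-fold higher number from compound 3 to compound 4 (0.03 log units; within the scatter). For compound 4 the expected value is 8.5 nM, with an estimated range from 5.5 nM to 13 nM.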

Compound 4, concentration for half-maximal effect: 9.55 nM
The estimate for compound 4 lay 1.1-fold (0.05 log units) below the measured number; the measured number falls inside the stated range.
By their numbers in this assay, from the lowest: compounds 2, 3, 1 and 4 (each within the scatter of the next).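

In this assay, adding methyl in place of hydrogen on an aromatic carbon can now be read directly, and the result is a 1.2-fold higher number from compound 3 to compound 4 (0.08 log units; within the scatter) with nothing else altered. At this position, ortho to a methyl group and two atoms from the ring oxygen, the added methyl therefore produces no difference that can be told apart from repeat-measurement noise. The second new comparison, a 1.0-fold higher number from compound 1 to compound 4 (0.02 log units; within the scatter) on the methyl-bearing core, shows that 5-sulfanyl-1,3,4-thiadiazol-2-yl and aminocarbamoyl on the side chain also cannot be told apart here, so neither change in these compounds separates one from another. No measurement is available that bears on why these steps are so small.

With all four compounds this close together, the numbers do not show which parts of the structure matter for the effect in the rat. Still open, from the compounds shown here alone, is whether something larger than methyl on this aromatic carbon, such as an ethyl group or a phenyl ring, or a side chain ending in an amine or a carboxylic acid, would give a step beyond the scatter.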